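A few compounds are considered here, and "the series" means these few. Any claim that something is new, unique, unknown or untested is made for them only; others in the source may bear on it.

Within the data shown here, in a functional assay on SW480 cells (Homo sapiens) for cytotoxicity, read by MTT assay, with a stated time of 72 h (a higher number here means a weaker inhibitor of growth, a lower number a stronger inhibitor of growth), compound 1 `Cc1ccc(/C=C(/C#N)C(=O)c2ccc[nH]2)cc1` gives 14000 nM, the only exact number so far. Compound 2 `N#C/C(=C/c1ccc(O)cc1)C(=O)c1ccc[nH]1` is reported only as a limit, < 10000 nM. Compound 3 `COc1ccc(/C=C(/C#N)C(=O)c2ccc[nH]2)cc1` remains unmeasured and carries methoxy in place of methyl on an aromatic carbon, para to a large group: methoxy in place of methyl on an aromatic carbon. Among the measured compounds shown here, the only measured step bearing on this, hydroxy in place of methyl, is an at least 1.4-fold lower number from compound 1 to compound 2 (0.14 log units; that floor lies within the scatter), so no step beyond the scatter is expected in this assay. The expected change is a 1.4-fold lower number from compound 1 to compound 3 (0.15 log units; within the scatter). Compound 3 is estimated at 10000 nM, with an expected range of 4000 nM to 25000 nM.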

Compound 3, concentration for 50% growth inhibition: < 10000 nM
Compound 3: only a limit was reported (the forecaster's own chance of this, stated with the estimate: 25%); the middle value sits exactly at the limit.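

In this assay, methoxy in place of methyl on an aromatic carbon, para to a large group, gives an at least 1.4-fold lower number from compound 1 to compound 3 (0.14 log units; that floor lies within the scatter), so a second oxygen-linked group at this position also ends in a limit rather than an exact number. The step between compound 2 and compound 3 cannot be read, and the series now rests largely on one assay limit: the limit of < 10000 nM in this assay, at which 2 of the 3 values shown sit.

Going by these compounds, how far compound 2 and compound 3 lie beyond that limit remains open. Also open, on these data alone, is whether an amine or a longer chain such as ethoxy at this position would give an exact number.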